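The compounds below may be only part of what the source reports. "The series", "measured", "known", "first", "only" and "open" are said of these compounds alone.

Of the compounds shown here, two have numbers so far. Compound 1 `O=c1[nH]c2ccccc2cc1/C=N/Nc1ccc([N+](=O)[O-])cc1` in a functional assay, read by spectrophotometry, with a stated time of 30 min (a lower number here means a stronger inhibitor, a higher number a weaker inhibitor), gives 170000 nM. Compound 2 `Cc1ccc2[nH]c(=O)c(/C=N/Nc3ccccc3)cc2c1` in this assay gives 62400 nM, the lowest of the two numbers, and it stands beyond the scatter from compound 1. Compound 3 `O=c1[nH]c2ccccc2cc1/C=N/Nc1ccccc1` is not yet measured; it differs from compound 2 by hydrogen in place of methyl on an aromatic carbon. A small change of this kind is expected to move the number little, with a 1.3-fold higher number from compound 2 to compound 3 (0.11 log units; within the scatter) as the estimated step. For compound 3 the expected number is 80000 nM, in the range 40000 nM to 160000 nM.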

Compound 3, half-maximal inhibitory concentration: 76500 nM
For compound 3 the middle estimate is 1.0-fold (0.02 log units) above the measured one; the range from low to high includes it.
By their numbers in this assay, from the lowest: compounds 2 and 3 (each within the scatter of the next); then compound 1.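

In this assay, hydrogen in place of methyl on an aromatic carbon of the fused system gives a 1.2-fold higher number from compound 2 to compound 3 (0.09 log units; within the scatter), so this single change does not separate the two compounds. Hydrogen in place of nitro on an aromatic carbon gives a 2.2-fold lower number from compound 1 to compound 3 (0.35 log units; beyond the scatter), a first one-place change that reads beyond the scatter, though a modest one. No measured evidence bears on the reason for either step. On these data alone, whether an amine or a carboxylic acid on the methyl-bearing carbon would move the number stays open. So does the outcome of replacing nitro with chlorine or a methoxy group.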